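Replacing the Fluoropyridine Arm of Compound 1 with Oxazole

The source may report more compounds than this note shows. Statements on the series, on what has been measured and on what is new or still open speak of the compounds shown alone.

Measured compounds: compound 1 `C[C@@H](Oc1cc2oc(=O)n(CCC(=O)O)c2cc1Cl)c1ccc(F)cn1`, 25.1 nM; compound 2 `O=C(O)CCn1c(=O)oc2cc(OCC3CCC3)c(Cl)cc21`, 1260 nM; compound 3 `CCc1cc2oc(=O)n(CCC(=O)O)c2cc1Cl`, 316 nM.

In an assay on HEK293 cells for inhibition of kynurenine 3-monooxygenase (Homo sapiens), read by LC-MS, with a stated time of 20 h (a lower number here means a stronger inhibitor, a higher number a weaker inhibitor), compound 1 gives the lowest number of the three, and its gaps to compound 3 and to compound 2 both lie beyond the scatter. Going by the values given here, the only step between measured compounds, a 4.0-fold lower number from compound 2 to compound 3 (0.60 log units; beyond the scatter), concerns a different position on the shared core and does not touch the arm that is varied here. Compound 4 `C[C@@H](Oc1cc2oc(=O)n(CCC(=O)O)c2cc1Cl)c1ncco1` differs from compound 1 by 1,3-oxazol-2-yl in place of 5-fluoropyridin-2-yl on a saturated chain carbon bound to an oxygen on an aromatic ring and a saturated chain carbon. Among the compounds with values here, no measured pair shows this exchange, so the expectation rests on the change alone: a modest rise in the number is estimated, a 2.5-fold higher number from compound 1 to compound 4 (0.40 log units; beyond the scatter). Compound 4 is expected to give about 63 nM, within 20 nM to 200 nM.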

Compound 4, half-maximal inhibitory concentration: 7940 nM
Beside the measured number, compound 4's estimate is 130-fold (2.10 log units) below it; measured number outside the range, above it.
By their numbers in this assay, from the lowest: compound 1; then compound 3; then compound 2; then compound 4.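

In this assay the arm on this saturated chain carbon proves decisive, and 1,3-oxazol-2-yl does not stand in for 5-fluoropyridin-2-yl (a 320-fold higher number from compound 1 to compound 4 (2.50 log units; beyond the scatter)). The exchange leaves compound 4 behind even the compounds lacking this arm, with ethyl (a 25-fold higher number from compound 3 to compound 4 (1.40 log units; beyond the scatter)) and with cyclobutylmethoxy (a 6.3-fold higher number from compound 2 to compound 4 (0.80 log units; beyond the scatter)) on the shared core. Nothing measured here explains this loss. On these data alone, whether a plain pyridin-2-yl or a phenyl arm would keep the low number of compound 1 stays open. Also open, as far as these compounds go, is whether the loss follows the ring size or the missing fluorine.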